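Trading 3,5-dimethylphenyl for 4-fluorophenyl on compound 3

A few compounds are considered here, and "the series" means these few. Any claim that something is new, unique, unknown or untested is made for them only; others in the source may bear on it.

Compound 3 `Cc1cc(C)cc(-c2nnc(COc3cnn(C(C)(C)C)c(=O)c3Cl)o2)c1` stands only at a limit in a functional assay on the whole organism for inhibition, with Mythimna separata as the target, with a stated time of 5 days; a lower number here means that less compound is needed, a higher number that more compound is needed for the effect: compound 3 gives > 300 ug/mL, which is a limit of the assay, not a number. Compound 2 `Cc1cc(C)cc(-c2nnc(COc3cnn(C(C)(C)C)c(=O)c3Cl)s2)c1` likewise gives a limit, > 300 ug/mL. Compound 1 `CC(C)(C)n1ncc(OCc2nnc(-c3ccc(Cl)cc3)s2)c(Cl)c1=O` gives 106 ug/mL. Among the measured compounds shown here, the single measured step, an at least 2.8-fold higher number from compound 1 to compound 2 (0.45 log units; beyond the scatter), runs opposite to the change now considered, and it ends at the limit described by the limit of > 300 ug/mL in this assay, at which 2 of the 3 values shown sit. Compound 4 `CC(C)(C)n1ncc(OCc2nnc(-c3ccc(F)cc3)o2)c(Cl)c1=O` differs from compound 3 by 4-fluorophenyl in place of 3,5-dimethylphenyl on an aromatic carbon. Reversing that earlier step points to a lower number, although compound 1 and compound 3 also differ elsewhere, and fluorine is not chlorine. The step of an at least 2.0-fold lower number from compound 3 to compound 4 (0.30 log units; that floor lies within the scatter) is therefore expected. Compound 4 is estimated at 150 ug/mL, between 60 ug/mL and 400 ug/mL.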

Compound 4, half-maximal effective concentration: 5.2 ug/mL
Beside the measured number, compound 4's estimate is 29-fold (1.46 log units) above it, outside the stated range (below it).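

Among the compounds shown here, putting 4-fluorophenyl in place of 3,5-dimethylphenyl gives an at least 57-fold lower number from compound 3 to compound 4 (1.76 log units; beyond the scatter) in this assay, so the group at this position can move the result much further than the earlier compounds showed. The step is only a floor, with compound 3 standing at a limit of the assay: the limit of > 300 ug/mL in this assay, at which 2 of the 4 values shown sit.

The compounds shown do not separate the gain of the fluorine from the loss of the two methyl groups. On these data alone, how a plain phenyl, a 4-methoxyphenyl or a 4-aminophenyl would fare at this position also remains open.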